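Replacing bromo with trifluoromethyl in an antiproliferative series

The compounds below may be only part of what the source reports. "The series", "measured", "known", "first", "only" and "open" are said of these compounds alone.

Measured in a functional assay on A549 cells (Homo sapiens) for antiproliferative activity, read by MTT assay, with a stated time of 24 h; a lower number here means a stronger inhibitor, a higher number a weaker inhibitor:
Compound 1 `COc1ccc(S(=O)(=O)n2c(-c3cn(-c4ccccc4)nc3-c3ccc(C(F)(F)F)cc3)nc3ccccc32)cc1`: 170 nM
Compound 2 `O=S(=O)(c1ccc(F)cc1)n1c(-c2cn(-c3ccccc3)nc2-c2ccc(C(F)(F)F)cc2)nc2ccccc21`: 1740 nM
Compound 3 `O=S(=O)(c1ccc(Br)cc1)n1c(-c2cn(-c3ccccc3)nc2-c2ccc(C(F)(F)F)cc2)nc2ccccc21`: 1690 nM

Compound 3, at 1690 nM, sits with compound 2 at the weak end of these three numbers, well apart from compound 1. Compound 4 `O=S(=O)(c1ccc(C(F)(F)F)cc1)n1c(-c2cn(-c3ccccc3)nc2-c2ccc(C(F)(F)F)cc2)nc2ccccc21` has trifluoromethyl in place of bromo on an aromatic carbon, para to a large group (trifluoromethyl in place of bromo on an aromatic carbon).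

Among the compounds with values here, three measured steps bear on this change. The closest is a 1.0-fold lower number from compound 2 to compound 3 (0.01 log units; within the scatter), where bromo in place of fluoro made no difference beyond the scatter. The large steps both involve the loss of methoxy: a 10-fold higher number from compound 1 to compound 2 (1.01 log units; beyond the scatter) and a 9.9-fold higher number from compound 1 to compound 3 (1.00 log units; beyond the scatter). Within the data shown here, compound 4 keeps no methoxy, and no measured compound carries trifluoromethyl at this place, so the guide is imperfect. In this assay, no change beyond the scatter is expected, given the flat step a 1.0-fold lower number from compound 2 to compound 3 (0.01 log units; within the scatter). The expected step is a 1.1-fold lower number from compound 3 to compound 4 (0.02 log units; within the scatter). For compound 4 the estimated value is 1600 nM, with an expected range of 700 nM to 3600 nM.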

Compound 4, half-maximal inhibitory concentration: 860 nM
Beside the measured number, compound 4's estimate is 1.9-fold (0.27 log units) above it; the range from low to high includes it.
By their numbers in this assay, from the lowest: compound 1; then compounds 4, 3 and 2 (each within the scatter of the next, the first and the last beyond it).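

In this assay, trifluoromethyl at this place on the aromatic ring gives a 2.0-fold lower number from compound 3 to compound 4 (0.29 log units; within the scatter), yet a 2.0-fold lower number from compound 2 to compound 4 (0.31 log units; beyond the scatter), so compounds 2, 3 and 4 no longer read as one flat level but as a chain in which only the two ends lie beyond the scatter of each other. Methoxy still stands apart, with a 5.1-fold higher number from compound 1 to compound 4 (0.70 log units; beyond the scatter), and compound 1 remains the strongest of the four. Nothing available here accounts for these steps.

On these data alone, whether an ethoxy group, a hydroxyl or an amine at this place would stand with compound 1 or with compounds 2, 3 and 4 remains open. Also open, as far as these compounds go, is whether methoxy would keep its lead if the other groups on the shared core were changed.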